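Halogenated phenylamides in the cyclopropane-linked series

This account rests on a few compounds, and the source may have more. Where it says the series, first, only, none or still open, it means among the compounds named here.

Measured so far in a functional assay on SiHa cells (Homo sapiens) for inhibition, read by CCK-8 assay, with a stated time of 72 h, tested at 10 uM; a higher number here means more inhibition of growth at the concentration tested, a lower number less inhibition of growth:
- compound 1, `CN(C)C(=O)c1cc2cnc(Nc3ccc(NC(=O)C4(C(=O)Nc5ccc(Br)cc5)CC4)cc3)nc2n1C1CCCC1`: 98.8%
- compound 2, `CN(C)C(=O)c1cc2cnc(Nc3ccc(NC(=O)C4(C(=O)Nc5cccc(Cl)c5)CC4)cc3)nc2n1C1CCCC1`: 97.3%

Compound 2 gives the lower of the two numbers in this assay, with compound 1 as its nearest neighbour; the gap between them is within the scatter, so the two cannot be ranked.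

Compound 3, `CN(C)C(=O)c1cc2cnc(Nc3ccc(NC(=O)C4(C(=O)Nc5ccc(F)cc5)CC4)cc3)nc2n1C1CCCC1`, is the next member to be measured. Its difference from compound 2 is 4-fluorophenyl in place of 3-chlorophenyl on an amide-type nitrogen.

Within the data shown here, one measured step bears on this change, the exchange of one halogenated phenyl group for another on the same amide-type nitrogen: a number 1.5 percentage points lower from compound 1 to compound 2 (within the scatter). That step did not move the number beyond the scatter, and both compounds sit close to complete inhibition of growth at the concentration tested. The move to 4-fluorophenyl is of the same kind and leaves every other part of the molecule untouched. No step beyond the scatter is therefore expected in this assay, and the estimated change is a number 2.3 percentage points lower from compound 2 to compound 3 (within the scatter) because a number 1.5 percentage points lower from compound 1 to compound 2 (within the scatter) stayed within the scatter for the comparable exchange.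

For compound 3 the expected value in this assay is 95%, with a likely range from 84% to 100%.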

Compound 3, percent growth inhibition at one concentration: 98%
Compound 3: the middle estimate sits 3 percentage points below what was measured; measured number inside the range.
By their numbers in this assay, from the lowest: compounds 2, 3 and 1 (each within the scatter of the next).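

In this assay the exchange on the amide-type nitrogen now extends to 4-fluorophenyl, with a number 0.7 percentage points higher from compound 2 to compound 3 (within the scatter) and no separation from the 3-chlorophenyl group. Among these compounds, compound 1 and compound 3 also form the first pair here in which only the halogen changes, and fluoro in place of bromo on an aromatic carbon gives a number 0.8 percentage points lower from compound 1 to compound 3 (within the scatter) as the result, so this single-atom exchange does not separate the two compounds at the concentration tested. Neither step can be ranked against the other, and nothing at hand accounts for how little these numbers move.

The compounds shown carry only a halogen on this phenyl ring, so it remains open whether a plain phenyl, a methoxy group, a nitrile, an amine or a carboxylic acid in that place would keep the number within the scatter. All three values also come from one concentration close to complete inhibition of growth, which leaves open whether these halogenated phenylamides would still read alike at lower concentrations.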